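The source may hold more compounds than are shown below. What is called first, only, known or untested is meant among the compounds shown, and "the series" means these compounds.

In a functional assay on RAW264.7 cells (Mus musculus) for inhibition (on this read-out higher numbers stand for weaker inhibition and lower numbers for stronger inhibition), compound 1 (`CCOC(=O)C1=CCCCC1S(=O)(=O)Nc1ccccc1F`) gives 75 nM, compound 2 (`CCOC(=O)C1=CCCCC1S(=O)(=O)Nc1ccc(F)cc1F`) gives 16 nM and compound 3 (`CCOC(=O)C1=CCCCC1S(=O)(=O)Nc1cc(F)c(F)cc1F`) gives 30 nM. Compound 2 thus stands clear of compound 1 and level, within the scatter, with compound 3.

The next compound, compound 4 (`O=C(OCCO)C1=CCCCC1S(=O)(=O)Nc1ccc(F)cc1F`), differs from compound 2 in one place: hydroxy in place of hydrogen on a saturated chain carbon, two bonds along the chain from an oxygen next to a carbonyl group. The same difference, read one bond further out, is ethyl to 2-hydroxyethyl.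

The measured steps bear on this change only indirectly. Both are fluoro in place of hydrogen on an aromatic carbon. The first, a 4.7-fold lower number from compound 1 to compound 2 (0.67 log units; beyond the scatter), is modest and beyond the scatter, while the second, a 1.9-fold higher number from compound 2 to compound 3 (0.27 log units; within the scatter), stays within it. For the measured compounds named here, neither step touches the ethyl, which compounds 1, 2 and 3 all share, so the data offer no direct precedent for the new hydroxy. They give only a rough yardstick of size, set by a 4.7-fold lower number from compound 1 to compound 2 (0.67 log units; beyond the scatter).

On that basis, a modest move toward weaker inhibition in this assay is expected, though with wide uncertainty, and a result within the scatter would be no surprise. The estimated step is a 2.5-fold higher number from compound 2 to compound 4 (0.40 log units; beyond the scatter). For compound 4, the expected value is 40 nM, with an estimated range from 12 nM to 130 nM.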

Compound 4, half-maximal inhibitory concentration: 330 nM
Estimate against measurement, compound 4: 8.3-fold (0.92 log units) below; the measured number lies above the stated range.
By their numbers in this assay, from the lowest: compounds 2 and 3 (each within the scatter of the next); then compound 1; then compound 4.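

The ester side chain is not a silent part of the molecule in this assay: going from ethyl to 2-hydroxyethyl gives a 21-fold higher number from compound 2 to compound 4 (1.31 log units; beyond the scatter) and is a large step toward weaker inhibition. For the compounds shown here, this single change is larger than either fluoro step on the aromatic ring, which were a 4.7-fold lower number from compound 1 to compound 2 (0.67 log units; beyond the scatter) and a 1.9-fold higher number from compound 2 to compound 3 (0.27 log units; within the scatter), so the earlier compounds gave no sign of how much this chain could matter. Nothing measured here accounts for the size of the step.

The compounds shown leave open whether the loss belongs to the hydroxy itself or to its place on the chain: methoxy in place of the hydroxy, a longer chain ending in hydroxy, or an amine or a carboxylic acid on the same chain would help to tell these readings apart. They also leave open whether 2-hydroxyethyl in place of ethyl would give a step of similar size on the core of compound 1 or of compound 3, which carry a different fluoro pattern on the aromatic ring.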